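Nitroimidazole oxadiazole thioethers: pyridyl aryl swap at compound 1

The source may report more compounds than this note shows. Statements on the series, on what has been measured and on what is new or still open speak of the compounds shown alone.

Compound 1 `Cc1ncc([N+](=O)[O-])n1CCSc1nnc(-c2ccc(N)cc2)o1` is the weakest of the three compounds measured in a functional assay on SGC-7901 cells (Homo sapiens) for cytotoxicity, read by MTT assay, with a stated time of 48 h (on this read-out higher numbers stand for weaker inhibition and lower numbers for stronger inhibition), giving 31700 nM. Compound 2 `CCOc1ccc(-c2nnc(SCCn3c([N+](=O)[O-])cnc3C)o2)cc1` gives 14100 nM and compound 3 `COc1ccc(-c2nnc(SCCn3c([N+](=O)[O-])cnc3C)o2)c(O)c1` gives 11700 nM in this assay. For the measured compounds named here, the one single-point step available is a 2.2-fold lower number from compound 1 to compound 2 (0.35 log units; beyond the scatter), which replaces the aryl substituent of compound 1 and moves the number down by a modest amount.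

Compound 4 `Cc1ncc([N+](=O)[O-])n1CCSc1nnc(-c2cccnc2)o1` changes the same end of the molecule: pyridin-3-yl in place of 4-aminophenyl on an aromatic carbon. Going by the values given here, no measured pair exchanges the whole ring, so the step from compound 2 bears only loosely; it shows that altering the aryl group of compound 1 shifts this assay by a small margin. The expected step is therefore small, with the direction uncertain, and a change within the scatter is plausible.

The estimate for compound 4 in this assay is 25000 nM, with a range of 10000 nM to 60000 nM, which corresponds to an expected 1.3-fold lower number from compound 1 to compound 4 (0.10 log units; within the scatter).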

Compound 4, half-maximal inhibitory concentration: 31600 nM
Compound 4: middle estimate off by 1.3-fold (0.10 log units), on the low side; low and high end bracket the measured number.
By their numbers in this assay, from the lowest: compounds 3 and 2 (each within the scatter of the next); then compounds 4 and 1 (each within the scatter of the next).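

In this assay, pyridin-3-yl in place of 4-aminophenyl gives a 1.0-fold lower number from compound 1 to compound 4 (0.00 log units; within the scatter), so at this position an aromatic ring with 1 hetero atom and 0 hydrogen-bond donors leaves the number unchanged within the scatter. The ethoxy exchange gave a 2.2-fold lower number from compound 1 to compound 2 (0.35 log units; beyond the scatter), which lies beyond the scatter, so not every aryl change at this position is silent in this read-out. No measured property of these compounds is available to account for the flat step.

Open, from the compounds shown here alone, is whether pyridin-4-yl or pyridin-2-yl matches pyridin-3-yl here, or whether the position of the ring nitrogen matters. Also open, going by these compounds, is how a carboxylic acid or a dimethylamino group on the ring at this position would move the number.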